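The source may hold more compounds than are shown below. What is called first, only, known or untested is meant among the compounds shown, and "the series" means these compounds.

Measured so far in a functional assay on NCI-H460 cells (Homo sapiens) for antiproliferative activity, read by MTT assay, with a stated time of 48 h; a higher number here means a weaker inhibitor, a lower number a stronger inhibitor:
Compound 1 `COc1cc(-c2cccc3nc(-c4ccc(Cl)cc4)oc23)cc(OC)c1OC`: > 25000 nM, a limit and not a number
Compound 2 `COc1cc(-c2nc3cccc(-c4cc(OC)c(OC)c(OC)c4)c3o2)ccc1O`: 2000 nM

Within the data shown here, compound 2, at 2000 nM, holds the only true number so far in this assay. Compound 3 `COc1cc(-c2cccc3nc(-c4ccc(N)cc4)oc23)cc(OC)c1OC` differs from it by 4-aminophenyl in place of 4-hydroxy-3-methoxyphenyl on an aromatic carbon. Among the measured compounds shown here, one measured step bears on this place, the large at least 12-fold lower number from compound 1 to compound 2 (1.09 log units; beyond the scatter), which lies beyond the scatter. Compound 3 gives up the 4-hydroxy-3-methoxyphenyl of that step, so a modest move towards a higher number is expected, smaller than the measured step. The expected step is a 2.5-fold higher number from compound 2 to compound 3 (0.40 log units; beyond the scatter). For compound 3 the estimated value is 5000 nM, with an expected range from 700 nM to 25000 nM.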

Compound 3, half-maximal inhibitory concentration: 310 nM
The estimate for compound 3 lay 16-fold (1.21 log units) above the measured number; measured number below the stated range.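

Among these compounds, at this place, on the aromatic carbon next to the ring nitrogen and the ring oxygen, the 4-hydroxy-3-methoxyphenyl of compound 2 proves not to be the only group that lowers the number in this assay: 4-aminophenyl in its place gives a 6.5-fold lower number from compound 2 to compound 3 (0.81 log units; beyond the scatter). Amino in place of chloro gives an at least 80-fold lower number from compound 1 to compound 3 (1.90 log units; beyond the scatter), so a single change on this phenyl ring separates the two. Compound 1 stands at a limit and not a number: the limit of > 25000 nM in this assay, at which 1 of the 3 values shown sits.

On these data alone, whether the free amine is needed stays open. A 4-(dimethylamino)phenyl or 4-acetamidophenyl at this place could answer that.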